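The source may report more compounds than this note shows. Statements on the series, on what has been measured and on what is new or still open speak of the compounds shown alone.

Compound 1 `CC1(C)S[C@@H]2/C(=C\C(=O)c3cc(F)cc(F)c3)C(=O)N2[C@H]1C(=O)OC(c1ccccc1)c1ccccc1` gives 19100 nM in a functional assay on A-375 cells (Homo sapiens) for cytotoxicity, read by MTT assay, with a stated time of 48 h; on this read-out lower numbers stand for stronger inhibition and higher numbers for weaker inhibition. Compound 2 `CC1(C)S[C@@H]2C/C(=C\C(=O)c3ccccc3)C(=O)N2[C@H]1C(=O)OC(c1ccccc1)c1ccccc1` gives > 100000 nM in this assay, a value that is a limit of the assay and not a number.

Among the compounds with values here, compound 1 therefore stands alone as the only number measured in this assay, while the other value sits at the limit (the limit of > 100000 nM in this assay, at which 1 of the 2 values shown sits). Compound 3 `CC1(C)S[C@@H]2/C(=C\C(=O)c3ccc4ccccc4c3)C(=O)N2[C@H]1C(=O)OC(c1ccccc1)c1ccccc1` is not yet measured; it differs from compound 1 in one place: naphthalen-2-yl in place of 3,5-difluorophenyl on a carbonyl carbon. Within the data shown here, compound 1 and compound 2 differ from each other in more than one place, so their two values show only that one gives a number and the other a limit, and no step between measured compounds is available to guide the size of the change. The step from compound 1 to compound 3 is expected to be small, within the usual scatter, as a 1.3-fold lower number from compound 1 to compound 3 (0.10 log units; within the scatter). Compound 3 is therefore estimated at 15000 nM, within 4000 nM to 60000 nM.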

Compound 3, half-maximal inhibitory concentration: 36500 nM
Compound 3: middle estimate off by 2.4-fold (0.39 log units), on the low side; measured number inside the range.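

On the carbonyl carbon whose other neighbour is the double-bonded chain carbon, this assay now offers its first comparison of two groups, and naphthalen-2-yl in place of 3,5-difluorophenyl gives a 1.9-fold higher number from compound 1 to compound 3 (0.28 log units; within the scatter) as its step. This position therefore takes two six-membered aromatic rings of carbon only, with no fluorine, in place of one fluorinated ring, and the two compounds cannot be told apart in this assay. Nothing shown here accounts for this result.

From the compounds shown here alone, whether an amine or a carboxylic acid on the aromatic ring at this place would read the same remains open. Compound 2 gives > 100000 nM, which is a limit and not a number, and it differs from compound 1 in more than one place, so the part of the core that separates them is also left open.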